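A few compounds are considered here, and "the series" means these few. Any claim that something is new, unique, unknown or untested is made for them only; others in the source may bear on it.

Compound 3 `C=C(Br)C(=O)Nc1cccc(-c2cn3nc(Cc4ccccc4)sc3n2)c1` sits second from the top among the three numbers recorded here: in a functional assay on HeLa cells (Homo sapiens) for inhibition, read by cell counting, with a stated time of 4 days (a higher number here means a weaker inhibitor, a lower number a stronger inhibitor), compound 3 gives 4500 nM. Its nearest neighbour is compound 1 `C=C(Br)C(=O)Nc1cccc(-c2cn3nc(-c4ccc(F)cc4)sc3n2)c1`, which in this assay gives 870 nM, and the furthest is compound 2 `CCOc1ccc(-c2nn3cc(-c4cccc(N)c4)nc3s2)cc1`, which in this assay gives 94000 nM. For the measured compounds named here, compound 2 lacks the bromoacrylamide of compounds 1 and 3 and carries a free aniline, so no single-point step connects it to the others; its value only shows how far the weakest number lies from compound 3.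

The move to compound 4 `C=C(Br)C(=O)Nc1cccc(-c2cn3nc(-c4ccc(OCC)cc4)sc3n2)c1` is 4-ethoxyphenyl in place of benzyl on an aromatic carbon. One recorded step bears on it directly: a 5.2-fold higher number from compound 1 to compound 3 (0.71 log units; beyond the scatter), where an aryl group at this carbon was replaced by benzyl. Compound 4 restores an aryl group at the same place, though with ethoxy rather than fluorine, so the step is expected to run back in the opposite direction, toward a lower number, by roughly the size seen between compound 1 and compound 3.

On that basis compound 4 is expected to give about 1500 nM in this assay, within a range from 400 nM to 6000 nM, a step of a 3.0-fold lower number from compound 3 to compound 4 (0.48 log units; beyond the scatter).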

Compound 4, half-maximal inhibitory concentration: 1100 nM
Compound 4: middle estimate off by 1.4-fold (0.13 log units), on the high side; low and high end bracket the measured number.
By their numbers in this assay, from the lowest: compounds 1 and 4 (each within the scatter of the next); then compound 3; then compound 2.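

In this assay, 4-ethoxyphenyl in place of benzyl on this carbon of the five-membered aromatic ring gives a clear step (a 4.1-fold lower number from compound 3 to compound 4 (0.61 log units; beyond the scatter)), while ethoxy in place of fluoro on the phenyl ring gives a step that stays within the scatter (a 1.3-fold higher number from compound 1 to compound 4 (0.10 log units; within the scatter)), so compound 3, with its benzyl group, stands apart from both aryl compounds, compound 1 and compound 4. Compound 4 also ties compound 2 to the series for the first time through a single change, (1-bromoethenyl)carbonyl in place of hydrogen on the nitrogen on the aromatic ring, and this is the largest step shown (an 85-fold lower number from compound 2 to compound 4 (1.93 log units; beyond the scatter)). Nothing among the data shown accounts for either effect.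

Going by these compounds, it remains open whether the tolerance seen with fluoro and ethoxy on the phenyl ring extends to a very different substituent, such as an amine, a carboxylic acid or a longer alkoxy chain. On these data alone, it is also open how much of the large step depends on the bromine, since a plain acryloyl group or an acetyl group on that nitrogen would be needed to separate the bromine from the rest of the group.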